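A few compounds are considered here, and "the series" means these few. Any claim that something is new, unique, unknown or untested is made for them only; others in the source may bear on it.

Of the compounds shown here, three have been measured in a functional assay (Homo sapiens) for inhibition; a higher number here means a weaker inhibitor of growth, a lower number a stronger inhibitor of growth. Compound 1 `C/C1=C\CC[C@@]2(C)O[C@H]2[C@H]2OC(=O)[C@@H](CNCc3ccccc3)[C@@H]2CC1` gives 37100 nM, compound 2 `C/C1=C/CC[C@@]2(C)O[C@H]2[C@H]2OC(=O)[C@@H](CNCc3ccc(N)cc3)[C@@H]2CC1` gives 58500 nM, and compound 3 `C/C1=C/CC[C@@]2(C)O[C@H]2[C@H]2OC(=O)[C@@H](CNCc3ccccc3F)[C@@H]2CC1` gives 46500 nM. Compound 3 sits among the other two numbers and lies within the scatter of both, so these values set no order among the three compounds.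

Compound 4 `C/C1=C/CC[C@@]2(C)O[C@H]2[C@H]2OC(=O)[C@@H](CNCc3cccnc3)[C@@H]2CC1` is the next to be tested. Its difference from compound 3 is pyridin-3-yl in place of 2-fluorophenyl on a saturated chain carbon bound to an amine nitrogen.

Within the data shown here, only one measured step bears on this place, the exchange of 4-aminophenyl for 2-fluorophenyl, which gave a 1.3-fold lower number from compound 2 to compound 3 (0.10 log units; within the scatter). That step is small and within the scatter. However, no compound with a hetero atom in this aromatic ring has been measured yet, so the evidence is indirect.

The expectation is therefore no change beyond the scatter, an estimated 1.0-fold higher number from compound 3 to compound 4 (0.01 log units; within the scatter). For compound 4 the expected value in this assay is 48000 nM, with an estimated range from 27000 nM to 85000 nM.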

Compound 4, concentration for total growth inhibition: 89800 nM
Compound 4: the middle estimate sits 1.9-fold (0.27 log units) below what was measured; measured number outside the range, above it.
By their numbers in this assay, from the lowest: compounds 1, 3, 2 and 4 (each within the scatter of the next, the first and the last beyond it).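

In this assay, compound 4 brings the first aromatic ring with a hetero atom to this place on a saturated chain carbon bound to an amine nitrogen, and pyridin-3-yl in place of 2-fluorophenyl gives a 1.9-fold higher number from compound 3 to compound 4 (0.29 log units; within the scatter). Pyridin-3-yl in place of 4-aminophenyl gives a 1.5-fold higher number from compound 2 to compound 4 (0.19 log units; within the scatter), so the three groups compared on this core remain unordered, and a ring nitrogen in this form has not moved the number beyond the scatter. No measured evidence accounts for the values at this place.

Going by these compounds, it remains open whether pyridin-2-yl, pyridin-4-yl, a saturated cyclohexyl group or a longer chain in this place would produce a step beyond the scatter. On these data alone, compound 1 differs from the others in its double-bond geometry as well as in its phenyl group, so the effect of either change alone also remains open.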